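Phenyl in place of chloro: a first cytotoxicity estimate

The compounds below may be only part of what the source reports. "The series", "measured", "known", "first", "only" and "open" are said of these compounds alone.

Going by the values given here, in an ADME assay on U2OS cells (Homo sapiens) for cytotoxicity (a lower number here means that less compound is tolerated, a higher number that more compound is tolerated), compound 1 (`CC(C)(O)c1cc2c(-c3ccc(C(F)(F)F)cc3)nccc2[nH]1`) gives 72300 nM and compound 2 (`CC(C)(O)c1cc2c(Cl)nccc2[nH]1`) gives 15500 nM as the lower of the only two numbers so far, a gap that lies beyond the usual scatter. Compound 2 therefore marks the end of this small range at which less compound is tolerated.

Compound 3 (`CC(C)(O)c1cc2c(-c3ccccc3)nccc2[nH]1`) has not yet been measured. It has phenyl in place of chloro on an aromatic carbon, next to the ring nitrogen (phenyl in place of chloro on an aromatic carbon). Among the compounds with values here, no measured pair isolates this change, so the expectation is loose. Within the data shown here, the one guide is compound 1, which stands higher at 72300 nM and suggests an upward move. In this assay a moderate rise beyond the scatter is expected, estimated as the step of a 2.6-fold higher number from compound 2 to compound 3 (0.41 log units; beyond the scatter) and leaving more compound tolerated. Compound 3 is estimated at 40000 nM (expected range 15000 nM to 100000 nM).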

Compound 3, half-maximal cytotoxic concentration: 22200 nM
The estimate for compound 3 lay 1.8-fold (0.26 log units) above the measured number; low and high end bracket the measured number.
By their numbers in this assay, from the lowest: compounds 2 and 3 (each within the scatter of the next); then compound 1.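

In this assay, phenyl in place of chloro on this aromatic carbon gives a 1.4-fold higher number from compound 2 to compound 3 (0.16 log units; within the scatter) and so, on its own, adds a ring without a change that can be told from repeat-measurement scatter. The larger difference appears on the phenyl ring itself: hydrogen in place of trifluoromethyl gives a 3.3-fold lower number from compound 1 to compound 3 (0.51 log units; beyond the scatter) and is a modest step beyond the scatter, so among these three compounds it is the trifluoromethyl group that goes with more compound being tolerated. Nothing measured here bears on the reason for this.

Going by these compounds, it remains open whether only trifluoromethyl has this effect, or whether another group on the phenyl ring, such as methoxy or an amine, would move the number as well. Also open, on these data alone, is how a non-aromatic group, such as a short amine chain in place of chloro on this carbon, would compare.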